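Replacing a Methoxy Group with 2-Methylphenyl on a Shared Core

The source may hold more compounds than are shown below. What is called first, only, known or untested is meant among the compounds shown, and "the series" means these compounds.

Compound 1 `COc1cccc(C(=O)Nc2cccc(C(=O)O)c2)c1` and compound 2 `CC(C)CCOc1ccc(C(=O)Nc2cccc(C(=O)O)c2)cc1` share the same core and differ only in the group carried on the outer aromatic ring. Within the data shown here, in an assay on isolated protein for agonist activity at Bile acid receptor (Homo sapiens), read by TR-FRET, with a stated time of 3 h, in the absence of a further agent (on this read-out lower numbers stand for an effect already at smaller amounts and higher numbers for an effect only at larger amounts of compound), compound 1 gives 1040 nM, the highest of the two numbers measured so far. Compound 2 gives 215 nM in this assay, a clearly lower number, and the gap between the two lies beyond the usual scatter. Among the measured compounds shown here, because the two compounds differ in more than one place, no single step connects them; the values simply show that the larger substituent goes with the lower number.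

Compound 3 `Cc1ccccc1-c1cccc(C(=O)Nc2cccc(C(=O)O)c2)c1` has not been measured. It arises from compound 1 through the change (2-methylphenyl in place of methoxy on an aromatic carbon). A downward step of a 4.2-fold lower number from compound 1 to compound 3 (0.62 log units; beyond the scatter) is expected for compound 3 in this assay because compound 2, which carries a larger substituent than methoxy, gives 215 nM. Compound 3 is therefore estimated at 250 nM, with a range from 60 nM to 1000 nM.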

Compound 3, half-maximal effective concentration: 68 nM
Beside the measured number, compound 3's estimate is 3.7-fold (0.57 log units) above it; the range from low to high includes it.
By their numbers in this assay, from the lowest: compound 3; then compound 2; then compound 1.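

Among these compounds, this is the first change that can be read at a single place: in this assay, the step is a 15-fold lower number from compound 1 to compound 3 (1.18 log units; beyond the scatter), and it is large. At this position, meta to a large group, the core of compound 1 takes 2-methylphenyl, with its six-membered aromatic ring, in place of methoxy, and the number falls rather than rises; the hydrogen-bond acceptor of methoxy is thus not needed for a low number here. Nothing available explains why the number falls.

Still open, as far as these compounds go, is whether the ring alone accounts for the step or whether its methyl group contributes, which a plain phenyl group would test. A saturated ring such as cyclohexyl, or a ring bearing an amine, would show whether an aromatic ring is needed at this position.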